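The source may report more compounds than this note shows. Statements on the series, on what has been measured and on what is new or still open speak of the compounds shown alone.

Of the compounds shown here, three have been measured in an ADME assay on HEK293 cells (Homo sapiens) for cytotoxicity, read by MTT assay, with a stated time of 24 h; a higher number here means a weaker inhibitor, a lower number a stronger inhibitor. Compound 1 (`O=[N+]([O-])c1ccc2nc(NCc3ccc(C(F)(F)F)cc3)c(N3CCCCC3)nc2c1`) reads > 200 ug/mL, which is a limit of the assay and not a number. Compound 2 (`CN(C)CCCNc1nc2cc([N+](=O)[O-])ccc2nc1NCc1ccc(F)cc1`) gives 4.28 ug/mL and compound 3 (`COc1ccc(CNc2nc3ccc([N+](=O)[O-])cc3nc2NCCCN(C)C)cc1`) gives 38.6 ug/mL. Compound 3 therefore has the higher of the two actual numbers, with compound 2 as its nearest neighbour.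

The next compound is compound 4 (`CN(C)CCCNc1nc2cc([N+](=O)[O-])ccc2nc1NCc1cccc(C(F)(F)F)c1`), which has 3-(trifluoromethyl)phenyl in place of 4-methoxyphenyl on a saturated chain carbon bound to a nitrogen on an aromatic ring. Going by the values given here, the one measured step bearing on this change is a 9.0-fold higher number from compound 2 to compound 3 (0.96 log units; beyond the scatter), where methoxy took the place of fluoro on an aromatic carbon. Methoxy leaves in the change to compound 4, so a move to a lower number in this assay is expected. It is expected to be smaller than that measured step, since the entering group is not the same. Among the compounds with values here, no measured step links compound 1 to compound 4, so compound 1 sets no size here. The expected change is a 3.0-fold lower number from compound 3 to compound 4 (0.47 log units; beyond the scatter). For compound 4 the estimated value is 13 ug/mL, with an expected range from 3.5 ug/mL to 45 ug/mL.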

Compound 4, half-maximal inhibitory concentration: 7.99 ug/mL
For compound 4 the middle estimate is 1.6-fold (0.21 log units) above the measured one; the measured number falls inside the stated range.
By their numbers in this assay, from the lowest: compounds 2 and 4 (each within the scatter of the next); then compound 3. At a limit, above all of these: compound 1.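

In this assay, going by these compounds alone, on the saturated chain carbon bound to a nitrogen on an aromatic ring, the exchange of 4-methoxyphenyl for 3-(trifluoromethyl)phenyl gives a 4.8-fold lower number from compound 3 to compound 4 (0.68 log units; beyond the scatter), so the earlier step away from fluoro is not the only change at this place that moves the number beyond the scatter. Set against 4-fluorophenyl, the same entering group gives a 1.9-fold higher number from compound 2 to compound 4 (0.27 log units; within the scatter), which is within the scatter, so among compounds 2, 3 and 4 only 4-methoxyphenyl separates from the other two, and the larger group of compound 4 brings no measurable separation from compound 2. Nothing measured here gives a reason for these differences.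

Compounds 3 and 4 differ in both the group on the ring and the ring position it occupies, so the shown compounds leave open how much of the step belongs to each. From the compounds shown here alone, it also remains open how an unsubstituted phenyl, a 3-methoxyphenyl or a pyridine ring would read at this same place on the shared core.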